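The compounds below may be only part of what the source reports. "The series", "measured", "known", "first", "only" and "open" are said of these compounds alone.

Measured compounds:
- compound 1, `COc1ccc(N2CCN(C(=O)Cn3cnc([N+](=O)[O-])n3)CC2)cc1`: 133000 nM
- compound 2, `N#Cc1ccccc1N1CCN(CC(=O)N2CCN(c3ccccc3C#N)CC2)CC1`: 127000 nM

Both numbers come from an ADME assay on L6 cells (Rattus norvegicus) for cytotoxicity; a higher number here means a weaker inhibitor, a lower number a stronger inhibitor. In this assay compound 1 gives 133000 nM and compound 2 gives 127000 nM; the two values lie within the scatter of each other, so neither compound can be set apart from the other, and the two structures share no single point of difference that would let one read a step between them. Both sit in the weak range of the read-out.

The unmeasured compound is compound 3, `O=C(Cn1cnc([N+](=O)[O-])n1)N1CCN(C(=O)C2CC2)CC1`. It is derived from compound 1 by one change: cyclopropylcarbonyl in place of 4-methoxyphenyl on an amine nitrogen in a ring. Among the measured compounds shown here, no step between measured compounds bears on this change, so nothing shows what such a replacement does to the half-maximal inhibitory concentration. Given that compound 1 and compound 2, which differ widely in their substituents, both give numbers in the same weak range, the expectation for compound 3 is a step of a 1.1-fold higher number from compound 1 to compound 3 (0.05 log units; within the scatter) from compound 1, that is, none beyond the scatter. Compound 3 is therefore estimated at 150000 nM in this assay, with a range from 60000 nM to 400000 nM.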

Compound 3, half-maximal inhibitory concentration: 156000 nM
Compound 3: the middle estimate sits 1.0-fold (0.02 log units) below what was measured; low and high end bracket the measured number.
By their numbers in this assay, from the lowest: compounds 2, 1 and 3 (each within the scatter of the next).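

In this assay, among the compounds shown here, cyclopropylcarbonyl in place of 4-methoxyphenyl on an amine nitrogen in a ring gives a 1.2-fold higher number from compound 1 to compound 3 (0.07 log units; within the scatter) and so provides the first direct reading at this position, where the two compounds cannot be told apart. The change removes the six-membered aromatic ring of carbon only and brings in a three-membered non-aromatic ring of carbon only and a double bond outside aromatic rings, so within this pair the aromatic ring at this position is not required for a number in the same range. No independent measurement is available to explain this result.

This single pair cannot show whether the position is insensitive in general, and a primary amine, a carboxylic acid or a longer alkyl chain on the same nitrogen could still move the number beyond the scatter. On these data alone, it also remains open whether the same replacement would give a comparable step on a core other than that of compound 1, such as the core of compound 2.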